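The source may hold more compounds than are shown below. What is called first, only, known or untested is meant among the compounds shown, and "the series" means these compounds.

Measured so far in a physicochemical assay for solubility, measured as kinetic solubility; on this read-out higher numbers stand for higher solubility and lower numbers for lower solubility:
- compound 1 `CC(=O)Nc1c(F)cc(C(=O)N[C@H]2CC[C@H](O)CC2)cc1O[C@@H](C)c1ccccc1`: >= 159 ug/mL, a limit
- compound 2 `CNC(=O)c1cc(C(=O)N[C@H]2CC[C@H](O)CC2)n([C@@H](C)c2ccc(C(F)(F)F)cc2)n1`: >= 175 ug/mL, a limit

Compound 2 stands only at a limit, with no number yet known for it. Compound 3 `CNC(=O)c1cc(C(=O)N[C@H]2CC[C@H](O)CC2)n([C@@H](C)c2cccc(C)c2)n1` carries 3-methylphenyl in place of 4-(trifluoromethyl)phenyl on a saturated chain carbon bound to an aromatic nitrogen and a saturated chain carbon. No measured pair sizes this change. In this assay the expected outcome is an at least 1.1-fold lower number from compound 2 to compound 3 (0.06 log units; that floor lies within the scatter), with no shift beyond the scatter in either direction. For compound 3 the estimate is 150 ug/mL, with an expected range of 85 ug/mL to 170 ug/mL.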

Compound 3, solubility: >= 180 ug/mL
Compound 3: no number, only a limit; the forecaster's own chance of this, stated with the estimate: 70%; middle value at least 1.2-fold (0.07 log units) away from the limit.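

In this assay compound 2 gives >= 175 ug/mL, a limit. Compound 3 gives >= 180 ug/mL, also a limit, and no step can be read from compound 2 to compound 3. Still open, going by these compounds, are the actual numbers for both compounds, and with them the size and direction of any shift from 3-methylphenyl in place of 4-(trifluoromethyl)phenyl.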